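Urea in place of fluorocyclobutyl amide on the shared core

This account rests on a few compounds, and the source may have more. Where it says the series, first, only, none or still open, it means among the compounds named here.

Measured compounds:
compound 1, `O=C(C1CC(F)C1)N1CCc2nc(C#Cc3ccccc3)sc2C1`: > 10000 nM
compound 2, `O=S(=O)(N1CCCCC1)N1CCc2nc(C#Cc3ccccc3)sc2C1`: 780 nM

The account concerns compound 1 and its unmeasured relative compound 3, `O=C(N1CCCCC1)N1CCc2nc(C#Cc3ccccc3)sc2C1`. In an assay on HEK293 cells for negative allosteric modulation of metabotropic glutamate receptor 5 (Homo sapiens), read by FLIPR, with a stated time of 1 h (a higher number here means a weaker inhibitor, a lower number a stronger inhibitor), compound 1 gives > 10000 nM, which is a limit of the measurement and not a number, so only a range is known for it; this is the limit of > 10000 nM in this assay, at which 1 of the 2 values shown sits. Compound 2, which carries a sulfonyl-linked piperidine on the same core, is measured in this assay at 780 nM. For the measured compounds named here, no step between two measured compounds that differ in a single place is available, so nothing about the size of any change is known from the data themselves.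

Compound 3 differs from compound 1 by piperidin-1-yl in place of 3-fluorocyclobutyl on a carbonyl carbon. Since compound 1 sits at a limit, any downward move from it would be a gain in inhibition. The step from compound 1 to compound 3 is expected to be an at least 4.0-fold lower number from compound 1 to compound 3 (0.60 log units; beyond the scatter), a gain in the direction of stronger inhibition, with a size that cannot be pinned down because compound 1 gives only > 10000 nM. Compound 3 is accordingly estimated at 2500 nM, within a range from 500 nM to 10000 nM.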

Compound 3, half-maximal inhibitory concentration: > 10000 nM
Compound 3 was reported as a limit; the forecaster's own chance of this, stated with the estimate: 30%; middle value at least 4.0-fold (0.60 log units) from the limit.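

In this assay compound 3 gives > 10000 nM and this is a limit of the assay, not a number. For the compounds shown here, no step from compound 1 to compound 3 can be read, because both compounds sit at the same limit: the limit of > 10000 nM in this assay, at which 2 of the 3 values shown sit. The compounds shown leave open how far either lies beyond that limit, and so whether piperidin-1-yl in place of 3-fluorocyclobutyl on a carbonyl carbon changes inhibition at all.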